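A few compounds are considered here, and "the series" means these few. Any claim that something is new, unique, unknown or untested is made for them only; others in the source may bear on it.

Measured compounds:
- compound 1 `Cc1ccc(-n2nccn2)c(C(=O)N2C[C@H](/C=C/c3ccc(F)cn3)CC[C@H]2C)c1` gives 3 nM
- compound 2 `Cc1ccc(-n2nccn2)c(C(=O)N2C[C@H](/C=C\c3ccc(F)cn3)CC[C@H]2C)c1` gives 28 nM

Both were tested in an assay on cells for binding affinity to Orexin receptor type 2 (Homo sapiens), read by radioligand binding; on this read-out higher numbers stand for weaker inhibition and lower numbers for stronger inhibition. Compound 2 holds the highest of the two numbers, and the nearest comparison is compound 1, whose value sits lower by a 9.3-fold higher number from compound 1 to compound 2 (0.97 log units; beyond the scatter). The two share every atom and bond; what separates them is only the drawing of one double bond, (the fact that compounds 1 and 2 differ only in the configuration as drawn).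

Compound 3 `Cc1ccc(-n2nccn2)c(C(=O)N2C[C@H](C#Cc3cc(CO)ccn3)CC[C@H]2C)c1` has not been tested. Compared with compound 2 the change is 2-(4-(hydroxymethyl)pyridin-2-yl)ethynyl in place of 2-(5-fluoropyridin-2-yl)ethenyl on a saturated ring carbon. Within the data shown here, the only measured step, a 9.3-fold higher number from compound 1 to compound 2 (0.97 log units; beyond the scatter), concerns the geometry of a double bond that compound 3 no longer carries, so it does not speak directly to this change, and the group that enters is new to the set. No direction can be read from the data. Compound 3 is therefore expected to lie between the two measured values, and the step from compound 2 is estimated at a 2.8-fold lower number from compound 2 to compound 3 (0.45 log units; beyond the scatter), with wide room on either side, giving an estimate of 10 nM (range 2 nM to 60 nM).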

Compound 3, inhibition constant: 42 nM
Beside the measured number, compound 3's estimate is 4.2-fold (0.62 log units) below it; the measured number falls inside the stated range.
By their numbers in this assay, from the lowest: compound 1; then compounds 2 and 3 (each within the scatter of the next).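

In this assay, placing 2-(4-(hydroxymethyl)pyridin-2-yl)ethynyl on this saturated ring carbon in place of the 2-(5-fluoropyridin-2-yl)ethenyl of the less tightly binding double-bond form gives a 1.5-fold higher number from compound 2 to compound 3 (0.18 log units; within the scatter). Measured against the other double-bond form, the same exchange gives a 14-fold higher number from compound 1 to compound 3 (1.15 log units; beyond the scatter), so the size of the step depends on which form serves as the reference. The exchange alters the linking bond and the pyridine substituent together, and no measured property of these groups explains the outcome.

The compounds shown leave open how much of each step belongs to the triple bond and how much to the swap of fluorine for hydroxymethyl, a question that 2-(5-fluoropyridin-2-yl)ethynyl could separate. They also leave open how an aminomethyl group or a carboxylic acid would fare in place of the hydroxymethyl.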